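A Methylamino Swap on a Limit-Bound Nucleoside Core

A few compounds are considered here, and "the series" means these few. Any claim that something is new, unique, unknown or untested is made for them only; others in the source may bear on it.

The study begins with three nucleosides sharing one core, compound 1 `Nc1nc(N)c2c(-c3ccsc3)cn([C@@H]3O[C@H](CO)[C@@H](O)[C@H]3O)c2n1`, compound 2 `Cc1ncnc2c1c(-c1cccs1)cn2[C@@H]1O[C@H](CO)[C@@H](O)[C@H]1O` and compound 3 `COc1nc(N)nc2c1c(-c1ccccc1)cn2[C@@H]1O[C@H](CO)[C@@H](O)[C@H]1O`, each tested in a functional assay on HCT-116 cells (Homo sapiens), read by MTT assay, with a stated time of 72 h; on this read-out lower numbers stand for stronger inhibition and higher numbers for weaker inhibition. Compound 1 reaches only a limit of the assay, giving > 20000 nM. Compound 2 likewise stops at a limit, > 20000 nM. Compound 3 also returns a limit, > 20000 nM. Compound 2 thus stands with the others, as the limit of > 20000 nM in this assay, at which 3 of the 3 values shown sit, sums up, and no numbered value exists among them. The next compound, compound 4 `CNc1ncnc2c1c(-c1cccs1)cn2[C@@H]1O[C@H](CO)[C@@H](O)[C@H]1O`, differs from compound 2 in one place: methylamino in place of methyl on an aromatic carbon. Within the data shown here, with no measured step to lean on, no change beyond the scatter is expected in this assay, and another limit is the likeliest outcome. Compound 4 is therefore estimated at 25000 nM, within 8000 nM to 80000 nM. The expected step is a step that the limit leaves unreadable from compound 2 to compound 4.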

Compound 4, half-maximal inhibitory concentration: > 20000 nM
Compound 4: a limit, no number; the forecaster's own chance of this, stated with the estimate: 80%; the middle value does not contradict the limit.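

In this assay compound 2 and compound 4 both end at a limit, and the step of methylamino in place of methyl cannot be read. The compounds shown leave open whether any change on the shared core gives a numbered value.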